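Two Chlorines in Place of One Fluorine

The compounds below may be only part of what the source reports. "The series", "measured", "known", "first", "only" and "open" are said of these compounds alone.

Compound 3 `O=C(COCc1ccccc1)N1CCN(c2ccc(F)cc2)CC1` stands second highest of the three numbers measured in a functional assay on HEK293 cells for positive allosteric modulation of metabotropic glutamate receptor 5 (Homo sapiens), read by FLIPR and calcium flux (on this read-out higher numbers stand for an effect only at larger amounts of compound and lower numbers for an effect already at smaller amounts), giving 1100 nM. Compound 1 `O=C(COCc1ccccc1)N1CCN(c2ccccc2)CC1` gives 7100 nM, while compound 2 `O=C(COCc1ccccc1)N1CCN(c2ccc(Cl)cc2)CC1` gives 350 nM. Compound 4 `O=C(COCc1ccccc1)N1CCN(c2ccc(Cl)cc2Cl)CC1` has not been measured; it differs from compound 3 by 2,4-dichlorophenyl in place of 4-fluorophenyl on an amine nitrogen in a ring. Within the data shown here, two measured steps bear on this change. Putting chloro in place of hydrogen on the aromatic carbon gave a 20-fold lower number from compound 1 to compound 2 (1.31 log units; beyond the scatter), and putting fluoro in place of chloro gave a 3.1-fold higher number from compound 2 to compound 3 (0.50 log units; beyond the scatter), so a chloro rather than a fluoro on that aromatic carbon has so far gone with a lower number. Among the measured compounds shown here, the second chloro on the ring has no counterpart among the measured compounds, so its contribution is unknown and widens the range. Compound 4 is therefore estimated at 300 nM, expected to fall between 70 nM and 1300 nM. That estimate means an expected 3.7-fold lower number from compound 3 to compound 4 (0.56 log units; beyond the scatter), in line with the size of a 3.1-fold higher number from compound 2 to compound 3 (0.50 log units; beyond the scatter).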

Compound 4, half-maximal effective concentration: 1000 nM
The estimate for compound 4 lay 3.3-fold (0.52 log units) below the measured number; the measured number falls inside the stated range.
By their numbers in this assay, from the lowest: compound 2; then compounds 4 and 3 (each within the scatter of the next); then compound 1.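

In this assay, a chloro in place of hydrogen on an aromatic carbon no longer always goes with a lower number: the second chloro of 2,4-dichlorophenyl goes the other way (a 2.9-fold higher number from compound 2 to compound 4 (0.46 log units; beyond the scatter)), opposite to the first chloro (a 20-fold lower number from compound 1 to compound 2 (1.31 log units; beyond the scatter)). The step from 4-fluorophenyl to 2,4-dichlorophenyl therefore brings no readable change (a 1.1-fold lower number from compound 3 to compound 4 (0.04 log units; within the scatter)), so the advantage of chloro over fluoro seen with a single substituent does not carry over to this pair. Even so, the ring with two chloros keeps much of the gain over plain phenyl (a 7.1-fold lower number from compound 1 to compound 4 (0.85 log units; beyond the scatter)).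

From the compounds shown here alone, it remains open whether this reversal belongs to chloro itself or to the ring carbon it occupies, which a methyl or methoxy group on that carbon, or a chloro there alone, could help to separate. Nothing available explains the reversal.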